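Swapping Methylsulfonyl for Acetamido on the Benzyl Arm

The source may report more compounds than this note shows. Statements on the series, on what has been measured and on what is new or still open speak of the compounds shown alone.

Three compounds have been measured in an assay on CHO cells for displacement of a labelled ligand from 5-hydroxytryptamine receptor 1B (Homo sapiens); a lower number here means a stronger inhibitor, a higher number a weaker inhibitor:

compound 1 `CN(Cc1ccc(S(C)(=O)=O)cc1)C1CCN(CCCc2c[nH]c3ccc(-n4cnnc4)cc23)CC1`: 140 nM
compound 2 `c1cncc(CNC2CCN(CCCc3c[nH]c4ccc(-n5cnnc5)cc34)CC2)c1`: 140 nM
compound 3 `c1ccc2c(c1)CCC2NCC1CCN(CCCc2c[nH]c3ccc(-n4cnnc4)cc23)CC1`: 25 nM

Compound 1 stands level with compound 2 at the digits shown, and these two share the highest numbers of the three. Compound 3 lies furthest from compound 1, with a number smaller by a clear margin. For the measured compounds named here, the only step between measured compounds that differ in one place is a 5.6-fold lower number from compound 2 to compound 3 (0.75 log units; beyond the scatter), and it concerns the group on the saturated ring carbon, not the aromatic ring that is altered here.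

Compound 4 `CC(=O)Nc1ccc(CN(C)C2CCN(CCCc3c[nH]c4ccc(-n5cnnc5)cc34)CC2)cc1` differs from compound 1 by acetamido in place of methylsulfonyl on an aromatic carbon. Going by the values given here, no measured step touches this part of the structure, so there is no basis from the data for expecting a shift beyond the scatter in either direction. Compound 4 is therefore expected to give about 140 nM in this assay, most likely between 50 nM and 400 nM, an expected step of no change at the digits printed from compound 1 to compound 4 (within the scatter).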

Compound 4, half-maximal inhibitory concentration: 100 nM
For compound 4 the middle estimate is 1.4-fold (0.15 log units) above the measured one; the range from low to high includes it.
By their numbers in this assay, from the lowest: compound 3; then compounds 4, 1 and 2 (each within the scatter of the next).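

For the compounds shown here, this is the first measured change on the aromatic ring of the benzyl arm: in this assay, acetamido in place of methylsulfonyl gives a 1.4-fold lower number from compound 1 to compound 4 (0.15 log units; within the scatter). On this aromatic carbon, para to a large group, methylsulfonyl, with no hydrogen-bond donor, can thus be exchanged for acetamido, which has one, with the number staying within the scatter. No measurement shown here accounts for how closely the two compounds agree.

The compounds shown leave open whether other groups at this place, such as an amine or a carboxylic acid, would stay at the same level. They also leave open what a plain hydrogen on this carbon would give, and so whether either group contributes at all to the number.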